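Lengthening the Chain in Two Related Series

The source may report more compounds than this note shows. Statements on the series, on what has been measured and on what is new or still open speak of the compounds shown alone.

Compound 1 `CCCCCCCCCC(=O)NCC(C)(C)CC1=C(O)C(=O)c2ccccc2C1=O` and compound 2 `CCCCCCCCCCC(=O)NCC(C)(C)CC1=C(O)C(=O)c2ccccc2C1=O` share a core and differ by methyl in place of hydrogen on a saturated chain carbon, nine bonds along the chain from a carbonyl carbon. In an ADME assay on Vero cells (Chlorocebus sabaeus) for cytotoxicity, read by reporter gene assay, with a stated time of 4 days (a lower number here means a stronger inhibitor, a higher number a weaker inhibitor), compound 1 gives 15000 nM, and compound 2 gives 14900 nM. The step between them is a 1.0-fold lower number from compound 1 to compound 2 (0.00 log units; within the scatter). Compound 3 `CCCCCCCCCCC(=O)OCC(C)(C)CC1=C(O)C(=O)c2ccccc2C1=O` has a different core, and how it differs from compound 1 is not broken down here. In this assay compound 3 reaches only a limit, > 233000 nM. That value is the limit of > 233000 nM in this assay, at which 1 of the 3 values shown sits. Compound 4 `CCCCCCCCCCCC(=O)OCC(C)(C)CC1=C(O)C(=O)c2ccccc2C1=O` is compound 3 with methyl in place of hydrogen on a saturated chain carbon, ten or more bonds along the chain from a carbonyl carbon; this is the same kind of change as before, differing from it only in where along the chain from a carbonyl carbon it sits. The step expected here is a step that the limit leaves unreadable from compound 3 to compound 4, because the earlier change gave a 1.0-fold lower number from compound 1 to compound 2 (0.00 log units; within the scatter). Compound 4 is therefore expected to give about 250000 nM, likely between 100000 nM and 600000 nM, and most probably again only a limit.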

Compound 4, half-maximal inhibitory concentration: 249000 nM
The estimate for compound 4 lay 1.0-fold (0.00 log units) above the measured number; measured number inside the range.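

Among the compounds shown here, compound 3 gives only a limit, so no step to compound 4 can be read: the limit of > 233000 nM in this assay, at which 1 of the 4 values shown sits. The compounds shown leave open whether the added methyl changes the number at all between compound 3 and compound 4.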